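The source may hold more compounds than are shown below. What is called first, only, known or untested is meant among the compounds shown, and "the series" means these compounds.

Measured compounds:
compound 1, `NCc1cc(F)ccc1CN(Cc1nc2ccccc2[nH]1)C1CCCc2cccnc21`: 219 nM
compound 2, `NCc1cc(C(=O)O)ccc1CN(Cc1nc2ccccc2[nH]1)C1CCCc2cccnc21`: 126 nM

In a functional assay on CEM-CCRF cells for antagonist activity at C-X-C chemokine receptor type 4 (Homo sapiens), read by calcium flux (a higher number here means a weaker inhibitor, a lower number a stronger inhibitor), compound 2 gives the smaller of the two numbers shown, but the step of a 1.7-fold lower number from compound 1 to compound 2 (0.24 log units; within the scatter) is within the scatter, so compound 2 and compound 1 cannot be told apart on this assay. Compound 3, `COC(=O)c1ccc(CN(Cc2nc3ccccc3[nH]2)C2CCCc3cccnc32)c(CN)c1`, differs from compound 2 by methyl in place of hydrogen on an oxygen next to a carbonyl group. Within the data shown here, no measured step bears on this change: the only step on record, from compound 1 to compound 2, exchanges fluoro for carboxy on an aromatic carbon and was itself within the scatter, so it gives no guide to capping the carboxy as a methyl ester. With nothing to point either way, compound 3 is expected to land near compound 2, with a step of a 1.2-fold higher number from compound 2 to compound 3 (0.08 log units; within the scatter) that is not expected to exceed the scatter. The estimate for compound 3 in this assay is 150 nM, with a range from 60 nM to 400 nM.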

Compound 3, half-maximal inhibitory concentration: 39 nM
Compound 3: middle estimate off by 3.8-fold (0.59 log units), on the high side, outside the stated range (below it).
By their numbers in this assay, from the lowest: compound 3; then compounds 2 and 1 (each within the scatter of the next).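

In this assay, this position does respond to what it carries, which compound 1 and compound 2 could not show, since they stayed within the scatter of each other. Placing methyl on the oxygen next to the carbonyl group gives a 3.2-fold lower number from compound 2 to compound 3 (0.51 log units; beyond the scatter), so the carboxy and methoxycarbonyl groups can be told apart here. Methoxycarbonyl in place of fluoro on the same aromatic carbon gives a 5.6-fold lower number from compound 1 to compound 3 (0.75 log units; beyond the scatter), also beyond the scatter, and no evidence is available to explain either step.

The compounds shown leave open whether this lower number is particular to the methyl ester or would also appear with an ethyl ester, a primary amide or a nitrile. They also leave open how a hydroxymethyl group would compare at this position.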